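Side-chain change from compound 2 to compound 4

A few compounds are considered here, and "the series" means these few. Any claim that something is new, unique, unknown or untested is made for them only; others in the source may bear on it.

Compounds measured in an assay on a protein complex for inhibition of CDK8/Cyclin C (Homo sapiens), with a stated time of 1 h, tested at 10 uM; on this read-out lower numbers stand for less inhibition and higher numbers for more inhibition at the one concentration tested (going by the name of the read-out):
compound 1 `CCOC(=O)/C=C/c1ccncc1-c1ccc2[nH]ccc2c1` — 100%
compound 2 `NC(=O)/C=C/c1ccncc1-c1ccc2ccccc2c1` — 102%
compound 3 `O=C(O)CCNC(=O)/C=C/c1ccncc1-c1ccc2ccccc2c1` — 91%

Compound 2 holds the highest of the three numbers; compound 1 lies within the scatter of it, and compound 3 is the furthest from it. Going by the values given here, the one step between measured neighbours is a number 11 percentage points lower from compound 2 to compound 3 (beyond the scatter), a modest loss beyond the scatter, from a 2-carboxyethyl in place of hydrogen on an amide-type nitrogen.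

Compound 4 `COC(=O)CCc1ccncc1-c1ccc2ccccc2c1` is not yet measured. It differs from compound 2 by 2-(methoxycarbonyl)ethyl in place of 2-carbamoylethenyl on an aromatic carbon. Among the compounds with values here, no measured step covers this change directly. The step from compound 2 to compound 3 touches only the amide-type nitrogen and keeps the ethenyl link. Compound 1 carries an ester on an ethenyl link but differs from compound 2 in two places, so its value and that of compound 2 can only be read side by side, and they sit within the scatter of each other. On these data alone, the fall in the count of double bonds outside aromatic rings and the loss of the hydrogen-bond donor are untested in this set. A modest drop is expected in this assay, a number 20 percentage points lower from compound 2 to compound 4 (beyond the scatter), with wide uncertainty. Compound 4 is estimated at 82%, within a range of 55% to 100%.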

Compound 4, a percentage reported as inhibition, at one concentration (the size of the read-out at that concentration, not a potency): 98%
Compound 4: the middle estimate sits 16 percentage points below what was measured, and the stated range covers the measured number.
By their numbers in this assay, from the lowest: compounds 3, 4, 1 and 2 (each within the scatter of the next, the first and the last beyond it).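

In this assay, 2-(methoxycarbonyl)ethyl in place of 2-carbamoylethenyl on the aromatic carbon opposite the ring nitrogen gives a number 4 percentage points lower from compound 2 to compound 4 (within the scatter), so the number stays level across a change of the whole side chain at the one concentration tested. The exchange removes both the ethenyl double bond and the amide hydrogen, and compound 4 shows that the read-out at this concentration depends on neither being present in this side chain, whereas the change confined to the amide-type nitrogen gives a number 11 percentage points lower from compound 2 to compound 3 (beyond the scatter). No measurement bears on why the side chain can be exchanged in this way.

Going by these compounds alone, the single step changes the link and the terminal group together, so their separate contributions remain open, as does the response to a terminal amine or a longer chain at this position. With compound 2 and compound 4 lying within the scatter of each other at one concentration, any difference in potency between them also remains unresolved, and a concentration series would be needed to show one.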